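A few compounds are considered here, and "the series" means these few. Any claim that something is new, unique, unknown or untested is made for them only; others in the source may bear on it.

Compound 2 `CCN(CC)CCCOc1ccc(C(=O)/C=C/c2ccc(N(C)C)cc2)c(O)c1` has the lowest number of the three compounds measured in an assay on isolated protein for inhibition of Amine oxidase [flavin-containing] B (Homo sapiens) (on this read-out higher numbers stand for weaker inhibition and lower numbers for stronger inhibition), giving 4100 nM. Compound 1 `CN(C)c1ccc(/C=C/C(=O)c2ccc(N(C)C)cc2O)cc1` gives 12100 nM, and compound 3 `CCN(CCCOc1ccc(C(=O)/C=C/c2ccc(N(C)C)cc2)c(O)c1)Cc1ccccc1` gives 13100 nM. Compound 4 `COc1ccc(C(=O)/C=C/c2ccc(N(C)C)cc2)c(O)c1` differs from compound 2 by hydrogen in place of 2-(diethylamino)ethyl on a saturated chain carbon bound to an oxygen on an aromatic ring. For the measured compounds named here, two measured steps bear on this change. The step of a 3.0-fold lower number from compound 1 to compound 2 (0.47 log units; beyond the scatter) shows the number falling when the 3-(diethylamino)propoxy group enters, and the step of a 3.2-fold higher number from compound 2 to compound 3 (0.50 log units; beyond the scatter) shows it rising when that amine is altered. Since compound 4 keeps neither the amine nor the dimethylamino group of compound 1, a modest rise in this assay is expected, amounting to a 2.4-fold higher number from compound 2 to compound 4 (0.39 log units; beyond the scatter). Compound 4 is therefore estimated at 10000 nM, within a range from 3000 nM to 30000 nM.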

Compound 4, half-maximal inhibitory concentration: 210 nM
Beside the measured number, compound 4's estimate is 48-fold (1.68 log units) above it, outside the stated range (below it).
By their numbers in this assay, from the lowest: compound 4; then compound 2; then compounds 1 and 3 (each within the scatter of the next).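

In this assay, cutting the side chain back to methoxy gives a 20-fold lower number from compound 2 to compound 4 (1.29 log units; beyond the scatter) and thus shows that, at this oxygen, the small ether does far better than the 3-(diethylamino)propoxy group. Methoxy in place of dimethylamino on an aromatic carbon gives a 58-fold lower number from compound 1 to compound 4 (1.76 log units; beyond the scatter) and makes the gain from the amine chain look small by comparison. Nothing measured here explains the size of these steps. The compounds shown leave open whether an ethoxy group or a free hydroxyl on this oxygen would hold the number as low.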